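Alkenyl thioether variation on the thromboxane receptor core

The source may hold more compounds than are shown below. What is called first, only, known or untested is meant among the compounds shown, and "the series" means these compounds.

Compound 1 `CSCSCC1C2CCC(O2)C1C/C=C\CCCC(=O)O` carries a methylsulfanyl on a saturated chain carbon bound to a sulfur of the shared core. Among the measured compounds shown here, in a functional assay on a cell-free system (plasma) for inhibition of thromboxane A2 receptor (Homo sapiens) (a higher number here means a weaker inhibitor, a lower number a stronger inhibitor), compound 1 gives 700 nM, the lowest of the three numbers measured so far. Compound 2 `CCSCC1C2CCC(O2)C1C/C=C\CCCC(=O)O` gives 5400 nM in this assay, and the step of a 7.7-fold higher number from compound 1 to compound 2 (0.89 log units; beyond the scatter) lies beyond the scatter. Compound 3 `CCC/C=C/CSCC1C2CCC(O2)C1C/C=C\CCCC(=O)O` gives 1300 nM in this assay; the step of a 1.9-fold higher number from compound 1 to compound 3 (0.27 log units; within the scatter) stays within the scatter, so compounds 1 and 3 cannot be placed in order on this number. Compound 4 `CC/C=C/CCSCC1C2CCC(O2)C1C/C=C\CCCC(=O)O` has not yet been measured. It differs from compound 1 as follows: pent-2-en-1-yl in place of methylsulfanyl on a saturated chain carbon bound to a sulfur. For the measured compounds named here, the step that bears most directly on this change is the one to compound 3, where pent-1-en-1-yl entered in place of methylsulfanyl and gave a 1.9-fold higher number from compound 1 to compound 3 (0.27 log units; within the scatter), a shift within the scatter; the step of a 4.2-fold lower number from compound 2 to compound 3 (0.62 log units; beyond the scatter) shows that the alkenyl chain gives a lower number than methyl. With pent-2-en-1-yl entering where pent-1-en-1-yl entered in compound 3, no step beyond the scatter is expected for compound 4 relative to compound 1. The estimate for compound 4 in this assay is 1200 nM, in a range from 450 nM to 3200 nM. This estimate for compound 4 means an expected step of a 1.7-fold higher number from compound 1 to compound 4 (0.23 log units; within the scatter).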

Compound 4, half-maximal inhibitory concentration: 700 nM
The estimate for compound 4 lay 1.7-fold (0.23 log units) above the measured number; low and high end bracket the measured number.
By their numbers in this assay, from the lowest: compounds 1, 4 and 3 (each within the scatter of the next); then compound 2.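

Read in this assay the exchange of methylsulfanyl for pent-2-en-1-yl on a saturated chain carbon bound to a sulfur shows no measurable cost (no change at the digits printed from compound 1 to compound 4 (within the scatter)), so the sulfur of the methylsulfanyl group can be absent from this place with no step beyond the scatter. The site of the double bond in the alkenyl chain cannot be separated on this number, since the exchange of pent-1-en-1-yl for pent-2-en-1-yl stays within the scatter (a 1.9-fold lower number from compound 3 to compound 4 (0.27 log units; within the scatter)), a finding that rests on this one pair. The step from the methyl compound is beyond the scatter (a 7.7-fold lower number from compound 2 to compound 4 (0.89 log units; beyond the scatter)), so compound 2 now stands apart from a second alkenyl compound as well as from compound 3, while compounds 1, 3 and 4 form one group that cannot be put in order.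

As far as these compounds go, whether a fully saturated pentyl chain, a longer chain such as an octyl group, or a chain carrying an amine would stay with that group remains open. Nothing available explains why these chains and methylsulfanyl sit together while methyl does not.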